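The compounds below may be only part of what the source reports. "The series", "measured", "known", "first", "only" and "open" are said of these compounds alone.

Measured so far:
compound 1 `CN(C(=O)NC(=O)c1ccc(F)c(F)c1)c1nc(C(F)(F)F)c(C(=O)N/N=C/c2ccc(C(F)(F)F)cc2)s1` — 6.26 ug/mL
compound 2 `CN(C(=O)NC(=O)c1c(F)cccc1F)c1nc(C(F)(F)F)c(C(=O)N/N=C/c2cccc(C(F)(F)F)c2)s1` — 27.9 ug/mL
compound 3 `CN(C(=O)NC(=O)c1ccc(F)c(F)c1)c1nc(C(F)(F)F)c(C(=O)N/N=C/c2cc(C(F)(F)F)cc(C(F)(F)F)c2)s1` — 5.47 ug/mL

In a functional assay on HepG2 cells (Homo sapiens) for inhibition, read by MTT assay, with a stated time of 72 h (a lower number here means a stronger inhibitor, a higher number a weaker inhibitor), compound 3 gives 5.47 ug/mL, the lowest of the three numbers. Its nearest neighbour is compound 1, whose value of 6.26 ug/mL lies within the scatter of that of compound 3, so no order between these two can be read. Compound 2 stands furthest away, with 27.9 ug/mL, beyond the scatter from compound 3; compound 2 differs from compound 3 in two places at once, so its gap cannot be assigned to either change.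

Compound 4 `CN(C(=O)NC(=O)c1ccc(F)c(F)c1)c1nc(C(F)(F)F)c(C(=O)N/N=C/c2cccc(C(F)(F)F)c2)s1` is reached from compound 3 by a single change: hydrogen in place of trifluoromethyl on an aromatic carbon. Going by the values given here, no measured pair isolates this change, since the only other meta-trifluoromethyl hydrazone, compound 2, also carries a different fluorination on the benzoyl part. Given that compound 1 at 6.26 ug/mL and compound 3 at 5.47 ug/mL sit within scatter of each other, a step of a 1.4-fold higher number from compound 3 to compound 4 (0.14 log units; within the scatter) is expected, most likely within the scatter, with a slight lean toward a higher number. Compound 4 is therefore estimated at 7.5 ug/mL, within 3.5 ug/mL to 16 ug/mL.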

Compound 4, half-maximal inhibitory concentration: 5.6 ug/mL
Beside the measured number, compound 4's estimate is 1.3-fold (0.13 log units) above it; low and high end bracket the measured number.
By their numbers in this assay, from the lowest: compounds 3, 4 and 1 (each within the scatter of the next); then compound 2.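

In this assay, hydrogen in place of trifluoromethyl on this aromatic carbon gives no readable difference (a 1.0-fold higher number from compound 3 to compound 4 (0.01 log units; within the scatter)), so the second trifluoromethyl group of compound 3 adds nothing that can be read here. 3-(Trifluoromethyl)phenyl in place of 4-(trifluoromethyl)phenyl likewise gives no readable difference (a 1.1-fold lower number from compound 1 to compound 4 (0.05 log units; within the scatter)), so the ring with one trifluoromethyl group shows no preference between these two placements. Going by these compounds alone, the only step beyond the scatter lies on the other side of the molecule, with 3,4-difluorophenyl in place of 2,6-difluorophenyl on a carbonyl carbon (a 5.0-fold lower number from compound 2 to compound 4 (0.70 log units; beyond the scatter)), and this single pair now isolates that change.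

Going by these compounds, whether this aromatic carbon accepts an amine or a carboxylic acid as readily as hydrogen and trifluoromethyl remains open. No measurement shown here accounts for any of these steps.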